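The source may hold more compounds than are shown below. What is called first, only, known or untested is meant among the compounds shown, and "the series" means these compounds.

Measured in a functional assay on MV4-11 cells (Homo sapiens) for inhibition, read by resazurin assay, with a stated time of 72 h; a higher number here means a weaker inhibitor of growth, a lower number a stronger inhibitor of growth:
compound 1 `CCn1cc(-c2ccnc(Nc3ccc(OC)cc3OC)n2)c2ccccc21` gives 3590 nM
compound 2 `CNc1nc(C)c(-c2ccnc(Nc3ccc(OC)cc3OC)n2)s1` gives 300 nM
compound 3 `COc1ccc(Nc2nccc(-c3sc(N(C)C)nc3C)n2)c(OC)c1` gives 170 nM

Among these three, compound 1 gives the highest number, so it is the weakest inhibitor of growth here; compound 2 comes nearest, compound 3 lies furthest away, and both gaps are beyond the scatter. Compound 4 `CCCn1cc(-c2ccnc(Nc3ccc(OC)cc3OC)n2)c2ccccc21` differs from compound 1 by methyl in place of hydrogen on a saturated chain carbon, two bonds along the chain from an aromatic nitrogen, a lengthening of a chain and nothing more. Among the compounds with values here, the only measured step, a 1.8-fold lower number from compound 2 to compound 3 (0.25 log units; within the scatter), concerns a methyl placed on a nitrogen of a different core, within the scatter, and offers little guidance for a chain carbon. Within the data shown here, with no closer precedent, the expectation is a step of a 1.2-fold lower number from compound 1 to compound 4 (0.08 log units; within the scatter), not beyond the scatter. Compound 4 is therefore estimated at 3000 nM, with a range of 1200 nM to 8000 nM.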

Compound 4, concentration for 50% growth inhibition: 3620 nM
Estimate against measurement, compound 4: 1.2-fold (0.08 log units) below, and the stated range covers the measured number.
By their numbers in this assay, from the lowest: compounds 3 and 2 (each within the scatter of the next); then compounds 1 and 4 (each within the scatter of the next).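

Methyl in place of hydrogen on a saturated chain carbon, two bonds along the chain from an aromatic nitrogen, turns ethyl to propyl and gives a 1.0-fold higher number from compound 1 to compound 4 (0.00 log units; within the scatter) in this assay. Within the data shown here, at this position, then, the two chains cannot be told apart, which the earlier compounds could not show, since no earlier pair differs at this chain. Nothing available gives a reason for this result. Still open, going by these compounds, is how a longer chain such as butyl, or a chain ending in an amine or a carboxylic acid, would read here.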